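A Ring Swap at the Carbonyl of Compound 1

The compounds below may be only part of what the source reports. "The series", "measured", "known", "first", "only" and "open" are said of these compounds alone.

Compound 1 `O=C(CSCc1nc2cc([N+](=O)[O-])ccc2[nH]1)c1ccccc1` holds the lowest number of the two measured in a functional assay on HCT-116 cells (Homo sapiens) for cytotoxicity, read by MTT assay, with a stated time of 48 h (on this read-out lower numbers stand for stronger inhibition and higher numbers for weaker inhibition), where compound 1 gives 12400 nM. Its only companion, compound 2 `O=C(CSCc1nc2cc([N+](=O)[O-])ccc2[nH]1)NNC(=S)Nc1ccccc1`, in this assay gives 29200 nM, a gap beyond the scatter. Compound 3 `CC1=NN(C(=O)CSCc2nc3cc([N+](=O)[O-])ccc3[nH]2)C(=O)C1` carries a group of 7 heavy atoms (4 carbon, 2 nitrogen, 1 oxygen; one five-membered non-aromatic ring with 2 hetero atoms) in place of a group of 6 heavy atoms (6 carbon; one six-membered aromatic ring of carbon only), on a carbonyl carbon. Among the compounds with values here, no step of this kind has been measured, so its size is uncertain; a modest change in either direction, or none beyond the scatter, seems plausible, and the step expected here, a 1.2-fold higher number from compound 1 to compound 3 (0.08 log units; within the scatter), is accordingly small. Compound 3 is estimated at 15000 nM, with a range from 5000 nM to 45000 nM.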

Compound 3, half-maximal inhibitory concentration: 5410 nM
Compound 3: middle estimate off by 2.8-fold (0.44 log units), on the high side; the range from low to high includes it.
By their numbers in this assay, from the lowest: compound 3; then compound 1; then compound 2.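

At this carbonyl carbon, putting the five-membered non-aromatic ring with 2 hetero atoms in place of phenyl gives a 2.3-fold lower number from compound 1 to compound 3 (0.36 log units; beyond the scatter) in this assay, so the phenyl ring is not needed to keep the number low on this read-out. The position therefore tolerates a non-aromatic ring, and the change moves the number beyond the scatter. Nothing available bears on why the number falls. Going by these compounds, whether a simple amine or a pyridine ring on the same carbonyl carbon would lower the number further remains open.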